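The compounds below may be only part of what the source reports. "The series", "measured", "known", "first", "only" and "open" are said of these compounds alone.

Three amides of the same amino acid have so far been tested in a functional assay on SiHa cells (Homo sapiens) for cytotoxicity, read by MTT assay, with a stated time of 48 h; a higher number here means a weaker inhibitor, a lower number a stronger inhibitor. Compound 1 `CCCCCCCCCCCCCCNC(=O)[C@@H](N)[C@@H](C)O` gives 11000 nM, compound 2 `CCCCCCCCCCCCCCCCCCNC(=O)[C@@H](N)[C@@H](C)O` gives 39500 nM, and compound 3 `CCCCCCCCCCCCNC(=O)[C@@H](NC(=O)c1nccc2ccccc12)[C@@H](C)O` gives 56600 nM. Of these three numbers, compound 2 stands second highest; its value and that of compound 3 lie within the usual scatter of each other, so no order can be read between them, whereas the gap to compound 1 is real: a 3.6-fold higher number from compound 1 to compound 2 (0.56 log units; beyond the scatter).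

Compound 4 `CCCCCCCCCCCCCCCCCCNC(=O)[C@@H](NS(=O)(=O)c1ccc(C)cc1)[C@@H](C)O` has not yet been measured. It differs from compound 2 in one place: (4-methylphenyl)sulfonyl in place of hydrogen on an amine nitrogen. Among the compounds with values here, no measured step concerns this amine nitrogen. Within the data shown here, the only step measured in one place, from compound 1 to compound 2, concerns the length of the chain and does not bear on the present change. Compound 3 and compound 1 differ in more than one place, so of that pair it can only be said that the number for compound 3 is higher than the number for compound 1.

Among the measured compounds shown here, with no direct precedent, the expected step is a 1.5-fold higher number from compound 2 to compound 4 (0.18 log units; within the scatter), toward a weaker inhibitor, and the uncertainty is wide. The value estimated for compound 4 is 60000 nM, with a range from 15000 nM to 200000 nM.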

Compound 4, half-maximal inhibitory concentration: 29800 nM
The estimate for compound 4 lay 2.0-fold (0.30 log units) above the measured number; low and high end bracket the measured number.
By their numbers in this assay, from the lowest: compound 1; then compounds 4, 2 and 3 (each within the scatter of the next).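

In this assay, within the data shown here, this is the first single change made at the amine nitrogen, and it gives a 1.3-fold lower number from compound 2 to compound 4 (0.12 log units; within the scatter) for the swap of hydrogen for (4-methylphenyl)sulfonyl. A step of this size cannot be told apart from repeat-to-repeat variation, even though the entering group brings 10 heavy atoms and a six-membered aromatic ring to a place that held only a hydrogen atom, so on the long chain of compound 2 this nitrogen can carry that large group with no measurable difference in this assay. No available measurement bears on why the number responds so little.

It remains open whether the same swap would give a similar result on the shorter chain of compound 1, whose number is the lowest of the set, since that pair with the sulfonyl group is not among the compounds shown. On these data alone, it also remains open whether a smaller methylsulfonyl group, a plain acetyl group or a phenylsulfonyl group carrying a carboxylic acid on its ring would behave in the same way at this amine nitrogen.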